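The source may hold more compounds than are shown below. What is called first, only, known or untested is meant among the compounds shown, and "the series" means these compounds.

Measured so far in an assay for inhibition of RAC-alpha serine/threonine-protein kinase (Homo sapiens), read by HTRF, with a stated time of 1 h; a higher number here means a weaker inhibitor, a lower number a stronger inhibitor:
- compound 1 `Cn1ncc(Cl)c1-c1cc(C(=O)NC2CNCCC2c2ccc(C(F)(F)F)cc2)oc1Cl`, which gives 7.2 nM
- compound 2 `Cn1ncc(Cl)c1-c1cc(C(=O)N[C@@H]2CN[C@H](CCO)C[C@H]2c2ccc(F)c(F)c2)oc1Cl`, which gives 0.98 nM
- compound 3 `Cn1ncc(Cl)c1-c1cc(C(=O)N[C@@H]2CN[C@H](CC(=O)O)C[C@H]2c2ccc(Cl)c(Cl)c2)oc1Cl`, which gives 1.94 nM

Compound 3 sits second highest of the three numbers. Its nearest neighbour is compound 2, whose number lies within the scatter of that of compound 3, so the two cannot be told apart on these data. Compound 1 gives a higher number than compound 3, and that gap lies beyond the scatter. For the measured compounds named here, no step between two measured compounds that differ in one place is available, so nothing so far sets the size of a single change.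

Compound 4 `Cn1ncc(Cl)c1-c1cc(C(=O)N[C@@H]2CN[C@H](CC(N)=O)C[C@H]2c2ccc(Cl)c(Cl)c2)oc1Cl` is not yet measured. It differs from compound 3 in one place: amino in place of hydroxy on a carbonyl carbon. Read one bond further out, the change is carboxy to carbamoyl, or carboxymethyl to carbamoylmethyl. Going by the values given here, with no comparable step in hand, the expectation for this assay is a step of modest size, not beyond the scatter, in either direction. The step from compound 3 to compound 4 is estimated at a 1.3-fold higher number from compound 3 to compound 4 (0.11 log units; within the scatter). For compound 4 the estimated value is 2.5 nM, with a range from 0.8 nM to 8 nM.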

Compound 4, half-maximal inhibitory concentration: 3.24 nM
For compound 4 the middle estimate is 1.3-fold (0.11 log units) below the measured one; measured number inside the range.
By their numbers in this assay, from the lowest: compounds 2, 3 and 4 (each within the scatter of the next, the first and the last beyond it); then compound 1.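

In this assay, for the compounds shown here, the exchange of hydroxy for amino on this carbonyl carbon gives the first single-place step, a 1.7-fold higher number from compound 3 to compound 4 (0.22 log units; within the scatter). This step lies within the scatter, so carboxy and carbamoyl cannot be told apart at this position on the chain, with the rest of the molecule held constant. The earlier compounds shown here could not show this, as no two of them differed in one place only.

Open, going by these compounds, is how a primary amine, a methyl ester or a longer chain ending in carbamoyl would read at this position in this assay, and whether the same exchange reads alike with a different aryl group on the shared core. No measurement at hand bears on the reason for this result.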